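Cyclising the amine tail of a melanocortin receptor 4 ligand

The compounds below may be only part of what the source reports. "The series", "measured", "known", "first", "only" and "open" are said of these compounds alone.

Compound 1 `CCC(C)[C@H](NCc1ccccc1F)c1cc(C(F)(F)F)ccc1N1CCN(C(=O)CCc2ccc(Cl)cc2Cl)CC1`: > 10000 nM in an assay on HEK293 cells for displacement of a labelled ligand from Melanocortin receptor 4 (Homo sapiens); a higher number here means a weaker inhibitor, a lower number a stronger inhibitor
Compound 2 `CCC(C)[C@H](NC[C@H](C)N)c1cc(C(F)(F)F)ccc1N1CCN(C(=O)CCc2ccc(Cl)cc2Cl)CC1`: 89 nM in this assay

The value of compound 1 is a limit of this assay and not a number. Compound 2 thus holds the only number shown, reached by an at least 110-fold lower number from compound 1 to compound 2 (2.05 log units; beyond the scatter). Compound 3 `CCC(C)[C@H](NC[C@H]1CCCN1)c1cc(C(F)(F)F)ccc1N1CCN(C(=O)CCc2ccc(Cl)cc2Cl)CC1` differs from compound 2 by pyrrolidin-2-yl in place of 1-aminoethyl on a saturated chain carbon bound to an amine nitrogen. For the measured compounds named here, the one measured step traded an aromatic ring for an amine-bearing chain; compound 3 keeps a chain amine, now closed into a ring, so only a small step is expected in this assay, a 1.5-fold lower number from compound 2 to compound 3 (0.17 log units; within the scatter). Compound 3 is estimated at 60 nM, between 15 nM and 300 nM.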

Compound 3, inhibition constant: 110 nM
The estimate for compound 3 lay 1.8-fold (0.26 log units) below the measured number; low and high end bracket the measured number.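

In this assay, pyrrolidin-2-yl and 1-aminoethyl cannot be told apart at this position, with a 1.2-fold higher number from compound 2 to compound 3 (0.09 log units; within the scatter), so the chain amine can be closed into a five-membered non-aromatic ring. In place of 2-fluorophenyl, this second amine-bearing group gives an at least 90-fold lower number from compound 1 to compound 3 (1.95 log units; beyond the scatter), so the large step is not confined to the open chain of compound 2. Compound 1 stands at a limit of the assay and not at a number: the limit of > 10000 nM in this assay, at which 1 of the 3 values shown sits.

From the compounds shown here alone, whether a hydroxyl in place of the amine, or a piperidin-2-yl ring, would hold this level stays open.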